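The source may report more compounds than this note shows. Statements on the series, on what has been measured and on what is new or still open speak of the compounds shown alone.

Measured compounds:

Compound 1 `CCOC(=O)c1cnc2ccc(-c3ccc(C(C)C)cc3)cc2c1`. In a functional assay on RD cells (Homo sapiens) for inhibition, read by luminescence and ATP content, with a stated time of 72 h (on this read-out lower numbers stand for higher toxicity in this test and higher numbers for lower toxicity in this test), compound 1 gives > 7400 nM, which is a limit of the assay and not a number.

Compound 2 `CCCCc1ccc(-c2ccc3ncc(C(=O)OCC)cc3c2)cc1`. In this assay compound 2 gives > 7400 nM, again a limit of the assay.

Compound 3 `CC(C)c1nc(-c2cnc3ccc(-c4ccc(N)cc4)cc3c2)no1`. In this assay compound 3 gives > 800 nM, also a limit of the assay.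

Compound 1 and compound 2 differ in one place, (butyl in place of isopropyl on an aromatic carbon). The step that the two limits leave unreadable from compound 1 to compound 2 cannot be read, since both values sit at a limit, as recorded in the limit of > 7400 nM in this assay, at which 2 of the 3 values shown sit. Compound 3 carries a different core; the difference between the core of compound 1 and the core of compound 3 is not broken down here.

Compound 4 `CCCCc1nc(-c2cnc3ccc(-c4ccc(N)cc4)cc3c2)no1` has not yet been measured in this assay. It differs from compound 3 by butyl in place of isopropyl on an aromatic carbon. This is the same kind of change as that from compound 1 to compound 2, but not the same: there the place was on an aromatic carbon of a six-membered aromatic ring of carbon only, para to a large group, whereas here it is on an aromatic carbon of a five-membered aromatic ring with 2 nitrogen and 1 oxygen, next to the ring nitrogen, next to the ring oxygen, two ring bonds from the ring nitrogen and two ring bonds from the ring atom that bears a large group.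

The step from compound 3 to compound 4 is expected to be small, a step that the limit leaves unreadable from compound 3 to compound 4, beside the unreadable step from compound 1 to compound 2; this rests on compound 3 sitting at the limit > 800 nM, as noted in the limit of > 800 nM in this assay, at which 1 of the 3 values shown sits, with no readable step of this kind to set a size. Compound 4 is estimated at 1600 nM, with a likely range from 600 nM to 5000 nM, and a limit rather than a number is the more probable outcome.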

Compound 4, half-maximal cytotoxic concentration: > 2500 nM
Compound 4: a limit, no number (the forecaster's own chance of this, stated with the estimate: 65%); at least 1.5-fold (0.19 log units) between middle value and limit.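

Compound 4 gives > 2500 nM in this assay, a limit of the assay and not a number, and compound 3 also sits at a limit, so no step can be read from compound 3 to compound 4. The compounds shown leave open whether butyl in place of isopropyl changes the half-maximal cytotoxic concentration on either core, as all values shown in this assay are limits.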